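Estimating growth inhibition for compound 4

The compounds below may be only part of what the source reports. "The series", "measured", "known", "first", "only" and "open" are said of these compounds alone.

Compound 1 `COc1cccc(C(=O)NNC(=O)c2ccc3[nH]c(-c4ccc([N+](=O)[O-])o4)nc3c2)c1` gives 15.6 ug/mL
Compound 2 `O=C(NNC(=O)c1ccc2[nH]c(-c3ccc([N+](=O)[O-])o3)nc2c1)c1cccc(Oc2ccccc2)c1` gives > 7.8 ug/mL
Compound 3 `O=C(NNC(=O)c1cc2ccccc2cc1O)c1ccc2[nH]c(-c3ccc([N+](=O)[O-])s3)nc2c1` gives 62.5 ug/mL

In a functional assay on MCF7 cells (Homo sapiens) for inhibition, read by sulforhodamine B assay, with a stated time of 48 h (a lower number here means a stronger inhibitor of growth, a higher number a weaker inhibitor of growth), compound 3, at 62.5 ug/mL, has the highest of the two actual numbers, and compound 1 gives 15.6 ug/mL. That gap lies beyond the scatter. Compound 2 stands at a limit, > 7.8 ug/mL, and not at a number. Going by the values given here, the one measured step, a step that the limit leaves unreadable from compound 1 to compound 2, offers no size to carry over.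

Compound 4 `COc1cccc(C(=O)NNC(=O)c2ccc3[nH]c(-c4ccc([N+](=O)[O-])s4)nc3c2)c1` differs from compound 3 as follows: 3-methoxyphenyl in place of 3-hydroxynaphthalen-2-yl on a carbonyl carbon, with 3-methoxyphenyl in place of 3-hydroxynaphthalen-2-yl on a carbonyl carbon. The same 3-methoxyphenyl sits in compound 1, at 15.6 ug/mL, on a core that is not identical, so a move toward that number is expected. The expected change is a 3.1-fold lower number from compound 3 to compound 4 (0.49 log units; beyond the scatter) in this assay, toward a lower number. For compound 4 the estimate is 20 ug/mL, with an expected range of 6 ug/mL to 65 ug/mL.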

Compound 4, concentration for 50% growth inhibition: 15.6 ug/mL
Estimate against measurement, compound 4: 1.3-fold (0.11 log units) above; measured number inside the range.
By their numbers in this assay, from the lowest: compounds 1 and 4 (each within the scatter of the next); then compound 3.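

In this assay, 3-methoxyphenyl in place of 3-hydroxynaphthalen-2-yl on a carbonyl carbon gives a 4.0-fold lower number from compound 3 to compound 4 (0.60 log units; beyond the scatter), which shows that the value responds to the group at this position when 5-nitrothiophen-2-yl is present. With 3-methoxyphenyl held in place, 5-nitrothiophen-2-yl in place of 5-nitrofuran-2-yl gives no change at the digits printed from compound 1 to compound 4 (within the scatter), so this pair does not separate the two nitro-bearing rings. No measured property shown here bears on either step.

The compounds shown leave open whether a 3-hydroxyphenyl group on the carbonyl carbon would stay near compound 4 or near compound 3. They also leave open how a naphthalen-2-yl group without the hydroxyl would read.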